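A few compounds are considered here, and "the series" means these few. Any claim that something is new, unique, unknown or untested is made for them only; others in the source may bear on it.

Compound 2 `COc1ccc(/C=N\NC(=S)NC(C)(C)CCC[C@](C)(O)[C@@H]2CC=C(C)CC2)cc1` carries a 4-methoxyphenyl group on a hydrazone arm that compound 1 `CC1=CC[C@@H]([C@@](C)(O)CCCC(C)(C)NC(=S)NN)CC1` does not have. Among the compounds with values here, in a functional assay on NCI/ADR cells (Homo sapiens) for cytotoxicity, read by sulforhodamine B assay (a lower number here means a stronger inhibitor of growth, a higher number a weaker inhibitor of growth), compound 1 gives 760 nM, while compound 2 gives 6730 nM, the highest of the two numbers, and the only measured step, an 8.9-fold higher number from compound 1 to compound 2 (0.95 log units; beyond the scatter), is a modest loss of potency. Compound 3 `CC1=CC[C@@H]([C@@](C)(O)CCCC(C)(C)NC(=S)N/N=C\c2ccc(O)cc2)CC1` differs from compound 2 by hydrogen in place of methyl on an oxygen on an aromatic ring, that is, methoxy to hydroxy. Within the data shown here, no measured step touches this oxygen, so the only guide is how much the whole aryl group cost in the step from compound 1 to compound 2, which changed far more than a single methyl. A change this small is expected to leave this assay roughly where compound 2 stands, with no step beyond the scatter, a 1.2-fold lower number from compound 2 to compound 3 (0.09 log units; within the scatter). Compound 3 is therefore estimated at 5500 nM, within a range of 2000 nM to 15000 nM.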

Compound 3, concentration for 50% growth inhibition: 8390 nM
Compound 3: middle estimate off by 1.5-fold (0.18 log units), on the low side; the measured number falls inside the stated range.
By their numbers in this assay, from the lowest: compound 1; then compounds 2 and 3 (each within the scatter of the next).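

Exchanging the methyl on this oxygen for hydrogen, methoxy to hydroxy, gives a 1.2-fold higher number from compound 2 to compound 3 (0.10 log units; within the scatter) in this assay so compound 2 and compound 3 cannot be told apart, and this small edit on the aromatic ring makes no readable difference. Compound 3 also stands well apart from the parent, with an 11-fold higher number from compound 1 to compound 3 (1.04 log units; beyond the scatter) and this shows that both aryl compounds shown, with either oxygen group, read beyond the scatter from compound 1. No measurement shown here explains why the number is higher with the aryl arm than with the free hydrazine end of compound 1.

As far as these compounds go, it remains open whether an amine or a carboxylic acid in place of this oxygen group would shift the reading. Also open, from the compounds shown here alone, is whether a smaller arm, such as a methyl in place of the aryl ring, would stay nearer to compound 1.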